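Notes on the step from compound 3 to compound 4

This account rests on a few compounds, and the source may have more. Where it says the series, first, only, none or still open, it means among the compounds named here.

Compound 3 `O=C1c2cc(COc3ccc(F)cc3)nn2CCN1c1ccc(F)cc1` has been measured in a functional assay on HEK293 cells for positive allosteric modulation of metabotropic glutamate receptor 5 (Homo sapiens), read by calcium flux (on this read-out lower numbers stand for smaller maximal responses and higher numbers for larger maximal responses), and gives 72%. Compound 1 `O=C1c2cc(COc3ccccc3)nn2CCN1c1ccc(F)cn1` gives 72% and compound 2 `O=C1c2cc(COc3ccccc3)nn2CCN1c1ncc(F)cn1` gives 72% in this assay, so compound 3 stands level with both within the scatter, and no order among the three can be drawn. Within the data shown here, the only single-point step measured so far, no change at the digits printed from compound 1 to compound 2 (within the scatter), concerns the group on the amide-type nitrogen in the ring and shows nothing beyond the scatter. Compound 4 `O=C1c2cc(COc3ccncc3)nn2CCN1c1ccc(F)cc1` is not yet measured; it differs from compound 3 as follows: pyridin-4-yl in place of 4-fluorophenyl on an oxygen on a saturated carbon. Among the measured compounds shown here, no measured step touches the group on the oxygen on the saturated carbon, so no step bears directly on this change; what is known is only that the three measured maximal responses sit close together. For compound 4 in this assay the expected value is therefore kept near that cluster, with a wide range for the untested position: the estimate is 72%, from 50% to 90%. The step this estimate implies, no change at the digits printed from compound 3 to compound 4 (within the scatter), is expected to lie within the scatter.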

Compound 4, largest response reached (Emax), in percent of the reference or control that the assay uses: 69%
Beside the measured number, compound 4's estimate is 3 percentage points above it; low and high end bracket the measured number.
By their numbers in this assay, from the lowest: compounds 4, 1, 2 and 3 (each within the scatter of the next).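

In this assay, the step at the group on the oxygen on a saturated carbon reads a number 3 percentage points lower from compound 3 to compound 4 (within the scatter), so the maximal response does not separate pyridin-4-yl from 4-fluorophenyl at this position. This single pair shows that, on this read-out, the carbon-only ring carrying fluorine can give way to a ring with a hetero atom and a hydrogen-bond acceptor without a step beyond the scatter. No supporting data are available to explain this result.

On these data alone, whether this holds for a non-aromatic group on the same oxygen, such as a piperidin-4-yl ring with its basic amine, a carboxylic acid or a longer alkyl chain, remains open. Also open, as far as these compounds go, is whether pyridin-4-yl behaves the same way with a different group on the amide-type nitrogen in the ring, such as 5-fluoropyridin-2-yl.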